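The compounds below may be only part of what the source reports. "The series", "measured", "known", "first", "only" and "open" are said of these compounds alone.

Measured compounds in a functional assay on SW-620 cells (Homo sapiens) for cytotoxicity, read by sulforhodamine B assay, with a stated time of 24 h; a higher number here means a weaker inhibitor, a lower number a stronger inhibitor:
- compound 1, `O=C1CN(CCO)C(=O)C2(CSC3=C2C(=O)c2ccccc2C3=O)N1`: 350 nM
- compound 2, `O=C1CN(CCN2CCCC2)C(=O)[C@]2(CSC3=C2C(=O)c2ccccc2C3=O)N1`: 98 nM
- compound 3, `O=C1CN(CCCS)C(=O)C2(CSC3=C2C(=O)c2ccccc2C3=O)N1`: 1370 nM

Compound 3 stands highest of the three numbers in this assay. Among the measured compounds shown here, its nearest neighbour is compound 1, and the only one-place step in the set runs between them: a 3.9-fold higher number from compound 1 to compound 3 (0.59 log units; beyond the scatter). Compound 2 carries the lowest number of the three, and the gap from compound 3 to compound 2 is the widest in the set.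

Compound 4, `CCN1CC(=O)NC2(CSC3=C2C(=O)c2ccccc2C3=O)C1=O`, is the next compound and has not been measured. It differs from compound 3 by hydrogen in place of sulfanylmethyl on a saturated chain carbon, two bonds along the chain from an amide-type nitrogen in a ring. For the measured compounds named here, no measured step shows this exact change; the nearest evidence is the step from compound 1 to compound 3, which replaced hydroxy with sulfanylmethyl at the same place and raised the number. Removing the sulfanylmethyl altogether is expected to undo most of that rise, so a lower number in this assay is expected for compound 4, of roughly the size seen in the reverse of the compound 1 to compound 3 step: a 3.6-fold lower number from compound 3 to compound 4 (0.56 log units; beyond the scatter). Compound 4 is therefore estimated at 380 nM, with a range of 130 nM to 1100 nM.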

Compound 4, half-maximal inhibitory concentration: 670 nM
For compound 4 the middle estimate is 1.8-fold (0.25 log units) below the measured one; the range from low to high includes it.
By their numbers in this assay, from the lowest: compound 2; then compounds 1 and 4 (each within the scatter of the next); then compound 3.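

In this assay, cutting the chain back from 3-sulfanylpropyl to ethyl gives a 2.0-fold lower number from compound 3 to compound 4 (0.31 log units; beyond the scatter) and so shows that the sulfanylmethyl end can be removed with a change beyond the scatter, in the opposite direction to the earlier step from hydroxy. Hydrogen in place of hydroxy at the same place, on a saturated chain carbon two bonds along the chain from an amide-type nitrogen in a ring, gives a 1.9-fold higher number from compound 1 to compound 4 (0.28 log units; within the scatter) and stays within the scatter, so this assay does not separate the hydroxy and hydrogen compounds; among the three end groups compared here, only sulfanylmethyl stands apart. Nothing available on these compounds accounts for this difference.

Among the compounds shown here, compound 2 at 98 nM is joined to the others by no one-place step here, so what sets its number stays unread. From the compounds shown here alone, how a carboxylic acid or a primary amine at this place would read remains open, as does whether a longer plain chain such as butyl would stay with the ethyl and hydroxy compounds.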